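A few compounds are considered here, and "the series" means these few. Any claim that something is new, unique, unknown or untested is made for them only; others in the source may bear on it.

Compound 1, `CCOC(=O)Cn1ncc2c(Nc3ccc(NS(=O)(=O)c4ccccc4)cc3)ncnc21`: in a functional assay on cells (Homo sapiens) for inhibition, read by MTT assay, with a stated time of 72 h (on this read-out higher numbers stand for weaker inhibition and lower numbers for stronger inhibition), compound 1 gives > 100 ug/mL, a limit of the assay.
Compound 2, `CCOC(=O)Cn1ncc2c(Nc3ccc(NC(=O)c4ccccc4)cc3)ncnc21`: compound 2 gives > 100 ug/mL, also a limit.
Compound 3, `O=C(O)Cn1ncc2c(Nc3ccc(NS(=O)(=O)c4ccccc4)cc3)ncnc21`: compound 3 gives > 100 ug/mL, again a limit.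

Compound 3 therefore stands nowhere that can be placed on a scale; it sits at the limit shared by the whole set, (the limit of > 100 ug/mL in this assay, at which 3 of the 3 values shown sit). Compound 4, `O=C(O)Cn1ncc2c(Nc3ccc(NC(=O)c4ccccc4)cc3)ncnc21`, has not been measured. Its difference from compound 3 is benzoyl in place of phenylsulfonyl on a nitrogen on an aromatic ring. The same exchange has been made once before, from compound 1 to compound 2, and that step reads a step that the two limits leave unreadable from compound 1 to compound 2. The other measured step, a step that the two limits leave unreadable from compound 1 to compound 3, is equally unreadable. Neither gives a direction or a size, and no value in the set is a number. For compound 4 the step that the limit leaves unreadable from compound 3 to compound 4 is expected to stay hidden at the limit, in no readable direction. Compound 4 is thus estimated at 150 ug/mL, with a range from 50 ug/mL to 500 ug/mL, most probably reported only as a limit once more.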

Compound 4, half-maximal inhibitory concentration: > 100 ug/mL
Compound 4: a limit, no number; the forecaster's own chance of this, stated with the estimate: 80%; the middle value is on the limit's open side.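

No new step can be read, since compound 4, like compound 2 and compound 3, gives a limit and not a number: the limit of > 100 ug/mL in this assay, at which 4 of the 4 values shown sit.

The compounds shown leave open how strongly any of them inhibits, and whether benzoyl or phenylsulfonyl, or hydrogen or ethyl on an oxygen next to a carbonyl group, gives stronger inhibition.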